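Hydroxypropynyl in place of butynyl on the deoxyuridine base

The source may hold more compounds than are shown below. What is called first, only, known or untested is meant among the compounds shown, and "the series" means these compounds.

Three compounds sharing a pyrimidinedione core joined to a sugar have been measured in a functional assay on L1210 cells (Mus musculus); a lower number here means a stronger inhibitor, a higher number a weaker inhibitor. Compound 1 `C#Cc1cn(C2O[C@H](CO)[C@@H](O)[C@@H]2O)c(=O)[nH]c1=O` gives 45 ug/mL. Compound 3 `CC(C)(C)C#Cc1cn(C2O[C@H](CO)[C@@H](O)[C@H]2O)c(=O)[nH]c1=O` gives 300 ug/mL. Compound 2 `CC#CCc1cn([C@H]2C[C@H](O)[C@@H](CO)O2)c(=O)[nH]c1=O` stands apart: for compound 2 the assay reports only a limit, > 1000 ug/mL, and not a number, which is the limit of > 1000 ug/mL in this assay, at which 1 of the 3 values shown sits. For the measured compounds named here, no single-change step joins any two of these measured compounds, so only their values can be compared, and compound 2 sits at the weak end of what is known while compounds 1 and 3 give measurable numbers.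

Compound 4 `O=c1[nH]c(=O)n([C@H]2C[C@H](O)[C@@H](CO)O2)cc1C#CCO` has not yet been measured. It differs from compound 2 in one place: 3-hydroxyprop-1-yn-1-yl in place of but-2-yn-1-yl on an aromatic carbon. The group that leaves and the group that enters each have four heavy atoms and a triple bond outside the ring, but only the entering group brings a hydrogen-bond donor and acceptor, and in it the triple bond sits directly on the aromatic carbon.

Because compound 2 shows only > 1000 ug/mL, a step toward stronger inhibition is expected for compound 4, of the size an at least 3.3-fold lower number from compound 2 to compound 4 (0.52 log units; beyond the scatter). Compound 4 is estimated at 300 ug/mL, within a range from 40 ug/mL to 1000 ug/mL.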

Compound 4, concentration for 50% inhibition: > 1000 ug/mL
Compound 4: only a limit was reported; the forecaster's own chance of this, stated with the estimate: 30%; middle value at least 3.3-fold (0.52 log units) from the limit.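

In this assay compound 4 gives > 1000 ug/mL, which is a limit of the assay and not a number. For the compounds shown here, compound 2 carries the same kind of limit, so no step between compound 2 and compound 4 can be read: the limit of > 1000 ug/mL in this assay, at which 2 of the 4 values shown sit. The compounds shown leave open whether 3-hydroxyprop-1-yn-1-yl in place of but-2-yn-1-yl on an aromatic carbon changes inhibition at all, and in which direction.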